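From Hydroxyphenyl to Furanyl on a Shared Core

The compounds below may be only part of what the source reports. "The series", "measured", "known", "first", "only" and "open" are said of these compounds alone.

Of the compounds shown here, two have been tested in an assay on isolated protein for inhibition of Amine oxidase [flavin-containing] B (Homo sapiens), read by fluorescence; on this read-out higher numbers stand for weaker inhibition and lower numbers for stronger inhibition. Compound 1 `O=C(/C=C/c1ccsc1)c1cc(O)c(O)c([N+](=O)[O-])c1` gives 42100 nM, and compound 2 `O=C(/C=C/c1cccc(O)c1)c1cc(O)c(O)c([N+](=O)[O-])c1` gives 55800 nM. The two share one core and differ only in the ring attached to the chain. On these two numbers compound 2 stands at the higher one, but the gap to compound 1 is within the usual scatter, so the two cannot really be told apart.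

Compound 3 `O=C(/C=C/c1ccco1)c1cc(O)c(O)c([N+](=O)[O-])c1` has not yet been measured in this assay. It differs from compound 2 in one place: furan-2-yl in place of 3-hydroxyphenyl on a double-bonded chain carbon bound to a double-bonded chain carbon. For the measured compounds named here, the only step that bears on this swap is the one that brought the hydroxyphenyl ring in for thiophen-3-yl, and because a 1.3-fold higher number from compound 1 to compound 2 (0.12 log units; within the scatter) stayed within the scatter, exchanging the hydroxyphenyl ring for another five-membered aromatic ring is expected to change little. Compound 3 is expected to land near compound 1, a step of a 1.2-fold lower number from compound 2 to compound 3 (0.09 log units; within the scatter) that should not exceed the scatter. Compound 3 is therefore estimated at 45000 nM, with a likely range from 15000 nM to 140000 nM.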

Compound 3, half-maximal inhibitory concentration: 68200 nM
For compound 3 the middle estimate is 1.5-fold (0.18 log units) below the measured one; measured number inside the range.
By their numbers in this assay, from the lowest: compounds 1, 2 and 3 (each within the scatter of the next).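

In this assay, furan-2-yl in place of 3-hydroxyphenyl on a double-bonded chain carbon bound to a double-bonded chain carbon gives a 1.2-fold higher number from compound 2 to compound 3 (0.09 log units; within the scatter), so this position tolerates the loss of the hydrogen-bond donor of 3-hydroxyphenyl and the move from a six-membered to a five-membered aromatic ring without a step beyond the scatter. The swap between the two hetero rings tells the same story, with furan-2-yl in place of thiophen-3-yl giving a 1.6-fold higher number from compound 1 to compound 3 (0.21 log units; within the scatter) and so showing no clear difference between them either. No supporting measurement is available to explain why these rings cannot be told apart.

Going by these compounds, all three compounds carry an aromatic ring at this place, so it remains open whether an amine, a carboxylic acid or a longer chain there would move the number beyond the scatter, in either direction. The shared core is also the same throughout, which leaves open how much of the inhibition depends on its nitro and hydroxyl groups rather than on the ring at the end of the chain.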